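Unbound fraction across aryl ether rings: pyrazine to pyridine

The compounds below may be only part of what the source reports. "The series", "measured", "known", "first", "only" and "open" are said of these compounds alone.

Compound 1 `C[C@@H](Cn1c(=O)[nH]/c(=N\c2ccc(Oc3nccs3)cc2)n(Cc2ccc(Cl)cc2)c1=O)C(=O)O` gives 0.006 in an ADME assay on the whole organism (plasma, Rattus norvegicus) for protein binding, using cassette dosing, at a dose of 1 mg/kg; a higher number here means a larger unbound share of the compound, a lower number a smaller unbound share
Compound 2 `C[C@@H](Cn1c(=O)[nH]/c(=N\c2ccc(Oc3cnccn3)cc2)n(Cc2ccc(Cl)cc2)c1=O)C(=O)O` gives 0.018 in this assay

Among the compounds with values here, compound 2, at 0.018 in this assay, holds the higher of the two numbers so far. Compound 3 `C[C@@H](Cn1c(=O)[nH]/c(=N\c2ccc(Oc3ccccn3)cc2)n(Cc2ccc(Cl)cc2)c1=O)C(=O)O` has pyridin-2-yl in place of pyrazin-2-yl on an oxygen on an aromatic ring. Within the data shown here, one measured step bears on this change: the exchange of 1,3-thiazol-2-yl for pyrazin-2-yl at the same place gave a 3.0-fold higher number from compound 1 to compound 2 (0.48 log units; beyond the scatter) and counts as modest. That single step is thin evidence, and neither measured ring is pyridin-2-yl. A value lying between those of the two measured compounds is expected, so the expected step is a 1.6-fold lower number from compound 2 to compound 3 (0.21 log units; within the scatter) and is small. The estimate for compound 3 is 0.011, with an expected range from 0.005 to 0.022 in this assay.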

Compound 3, unbound fraction: 0.01
Beside the measured number, compound 3's estimate is 1.1-fold (0.04 log units) above it, within the range that was stated.
By their numbers in this assay, from the lowest: compounds 1, 3 and 2 (each within the scatter of the next, the first and the last beyond it).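

In this assay, pyridin-2-yl in place of pyrazin-2-yl on an oxygen on an aromatic ring gives a 1.8-fold lower number from compound 2 to compound 3 (0.26 log units; within the scatter), and pyridin-2-yl in place of 1,3-thiazol-2-yl at the same place gives a 1.7-fold higher number from compound 1 to compound 3 (0.22 log units; within the scatter). Neither step leaves the scatter, so compound 3 cannot be told apart from either earlier compound. Within the data shown here, the step from 1,3-thiazol-2-yl to pyrazin-2-yl remains the only change at this position that stands beyond the scatter, and pyridin-2-yl adds a ring that separates clearly from neither.

Nothing available accounts for the differences among these rings. As far as these compounds go, how a phenyl ring, or a pyridin-2-yl ring carrying an amine, would compare at this position remains open, as does whether the same ring order would hold on a core other than the shared one.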